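This account rests on a few compounds, and the source may have more. Where it says the series, first, only, none or still open, it means among the compounds named here.

Compound 1 `Oc1cccc(-c2cc(-c3ccsc3)nc(-c3cccc(Cl)c3)c2)c1` gives 2510 nM in a functional assay on HCT-15 cells (Homo sapiens) for cytotoxicity, read by CCK-8 assay and cell counting, with a stated time of 2 days; a lower number here means a stronger inhibitor, a higher number a weaker inhibitor; compound 2 `Oc1cccc(-c2cc(-c3cccc(Cl)c3)nc(-c3ccco3)c2)c1` gives 2460 nM; compound 3 `Oc1cccc(-c2cc(-c3ccccc3)nc(-c3ccc(Cl)cc3)c2)c1` gives 8110 nM.

Among the three, compound 3 gives the highest number, and both compound 1 and compound 2 sit lower by more than the scatter. Compound 4 `Oc1cccc(-c2cc(-c3ccccc3)nc(-c3cccc(Cl)c3)c2)c1` differs from compound 3 in one place: 3-chlorophenyl in place of 4-chlorophenyl on an aromatic carbon. Among the measured compounds shown here, the only measured step, a 1.0-fold lower number from compound 1 to compound 2 (0.01 log units; within the scatter), concerns the other aryl group and stays within the scatter, so no step directly tests the chlorine position. Compounds 1 and 2 both carry 3-chlorophenyl and give lower numbers than compound 3, but each also differs in the second aryl group, so the expected effect is uncertain. Compound 4 is expected to give 3800 nM (range 1500 nM to 9000 nM), an estimated step of a 2.1-fold lower number from compound 3 to compound 4 (0.33 log units; beyond the scatter).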

Compound 4, half-maximal inhibitory concentration: 2550 nM
Beside the measured number, compound 4's estimate is 1.5-fold (0.17 log units) above it; measured number inside the range.
By their numbers in this assay, from the lowest: compounds 2, 1 and 4 (each within the scatter of the next); then compound 3.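

In this assay, among the compounds shown here, 3-chlorophenyl in place of 4-chlorophenyl on the carbon next to the ring nitrogen gives the first direct reading of the chlorine position (a 3.2-fold lower number from compound 3 to compound 4 (0.50 log units; beyond the scatter)). With 3-chlorophenyl kept, the other aryl group can be phenyl, furan-2-yl or thiophen-3-yl without a change beyond the scatter (a 1.0-fold higher number from compound 2 to compound 4 (0.02 log units; within the scatter); a 1.0-fold higher number from compound 1 to compound 4 (0.01 log units; within the scatter)). Nothing available explains why the chlorine position matters here.

Going by these compounds, whether an amine or a carboxylic acid in place of the chlorine would keep this number stays open. So does the contribution of the 3-hydroxyphenyl group.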